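A few compounds are considered here, and "the series" means these few. Any claim that something is new, unique, unknown or untested is made for them only; others in the source may bear on it.

Measured compounds:
compound 1 `O=C(N/N=C/c1cn(Cc2cc(-c3ccccc3)cnc2Cl)nn1)c1ccc(F)cc1`, 357 ug/mL
compound 2 `Cc1cnc(Cl)c(Cn2cc(/C=N/NC(=O)c3ccc(C(F)(F)F)cc3)nn2)c1`, 337 ug/mL

In an ADME assay on PBMC cells (Homo sapiens) for cytotoxicity, read by MTT assay, with a stated time of 72 h (on this read-out lower numbers stand for stronger inhibition and higher numbers for weaker inhibition), compound 1 gives 357 ug/mL, and in this assay compound 2 gives 337 ug/mL. Compound 2 has the lowest of the two numbers, but the gap to compound 1 lies within the scatter, so the two are not told apart.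

Compound 3 `O=C(N/N=C/c1cn(Cc2cc(-c3ccccc3)cnc2Cl)nn1)c1ccc(C(F)(F)F)cc1` differs from compound 2 by phenyl in place of methyl on an aromatic carbon. Among the measured compounds shown here, no step between measured compounds tests this change directly, so the estimate rests on the two values shown. The step from compound 2 to compound 3 is expected to be small, a 1.0-fold higher number from compound 2 to compound 3 (0.00 log units; within the scatter), within the scatter. Compound 3 is therefore estimated at 340 ug/mL, with a range from 200 ug/mL to 600 ug/mL.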

Compound 3, half-maximal inhibitory concentration: 282 ug/mL
Estimate against measurement, compound 3: 1.2-fold (0.08 log units) above, within the range that was stated.
By their numbers in this assay, from the lowest: compounds 3, 2 and 1 (each within the scatter of the next).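

Phenyl in place of methyl on the aromatic carbon para to the chloro group gives a 1.2-fold lower number from compound 2 to compound 3 (0.08 log units; within the scatter) in this assay, so this position takes a group of six heavy atoms instead of one with no difference this read-out can tell. Trifluoromethyl in place of fluoro, with phenyl held at this position, gives a 1.3-fold lower number from compound 1 to compound 3 (0.10 log units; within the scatter) and likewise does not separate the compounds. No accompanying measurement bears on these results. Going by these compounds, whether an amine, a carboxylic acid or a longer chain on this carbon would give a step beyond the scatter remains open.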